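Phenyl for hexyl on the ester side chain of compound 2

This account rests on a few compounds, and the source may have more. Where it says the series, first, only, none or still open, it means among the compounds named here.

Measured compounds in a functional assay on DU-145 cells (Homo sapiens) for cytotoxicity, read by MTT assay; on this read-out higher numbers stand for weaker inhibition and lower numbers for stronger inhibition:
- compound 1, `CC(C)=CC[C@@H](OC[C@@H](C)O)C1=CC(=O)c2c(O)ccc(O)c2C1=O`: 14300 nM
- compound 2, `CCCCCCC(C)(O)CC(=O)O[C@H](CC=C(C)C)C1=CC(=O)c2c(O)ccc(O)c2C1=O`: in this assay compound 2 gives only a limit, > 100000 nM
- compound 3, `CCC(CO[C@H](CC=C(C)C)C1=CC(=O)c2c(O)ccc(O)c2C1=O)OC(C)=O`: 25400 nM

Compound 2 stands at the limit (the limit of > 100000 nM in this assay, at which 1 of the 3 values shown sits); of the three compounds it alone gives no number. Among the compounds with values here, the one measured step between compounds that differ in a single place runs from compound 1 to compound 3, with 1-acetoxypropyl in place of 1-hydroxyethyl, and reads a 1.8-fold higher number from compound 1 to compound 3 (0.25 log units; within the scatter). That step sits on an ether side chain of the shared core and does not touch the part changed here.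

Compound 4, `CC(C)=CC[C@@H](OC(=O)CC(C)(O)c1ccccc1)C1=CC(=O)c2c(O)ccc(O)c2C1=O`, differs from compound 2 by phenyl in place of hexyl on a saturated chain carbon bound to an oxygen on a saturated carbon and two saturated chain carbons. Within the data shown here, no measured step bears on this exchange, so the account gives no direction to expect; the change may leave compound 4 at a limit as well or bring it into the measured range. Compound 4 is therefore expected to lie near 80000 nM, within 20000 nM to 300000 nM, which means an expected step of an at least 1.2-fold lower number from compound 2 to compound 4 (0.09 log units; that floor lies within the scatter).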

Compound 4, half-maximal inhibitory concentration: > 100000 nM
Compound 4 ended at the assay's limit; the forecaster's own chance of this, stated with the estimate: 50%; at least 1.2-fold (0.09 log units) between middle value and limit.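

In this assay compound 2 and compound 4 both end at a limit and not at a number, so phenyl in place of hexyl gives no readable step between them: the limit of > 100000 nM in this assay, at which 2 of the 4 values shown sit. The compounds shown leave open whether this exchange changes the read-out at all, and in which direction.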